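Ring for Chain on the Triazole Nitrogen

A few compounds are considered here, and "the series" means these few. Any claim that something is new, unique, unknown or untested is made for them only; others in the source may bear on it.

Three measured compounds share one core. Compound 1 `CN1C(=S)[C@@H](NC(=O)c2nc(Cc3ccccc3)n(C)n2)COc2ccccc21` bears hydrogen at the position in question and gives 2.5 nM in a functional assay on HT-29 cells (Homo sapiens) for inhibition, read by luminescence and CellTiter-Glo, with a stated time of 24 h; a lower number here means that less compound is needed, a higher number that more compound is needed for the effect. Compound 2 `CCn1nc(C(=O)N[C@H]2COc3ccccc3N(C)C2=S)nc1Cc1ccccc1` gives 17 nM, and compound 3 `CC(C)Cn1nc(C(=O)N[C@H]2COc3ccccc3N(C)C2=S)nc1Cc1ccccc1` gives 1230 nM, the highest of the three numbers. The steps that set these apart are all in one direction: a 6.8-fold higher number from compound 1 to compound 2 (0.83 log units; beyond the scatter), a 490-fold higher number from compound 1 to compound 3 (2.69 log units; beyond the scatter) and a 72-fold higher number from compound 2 to compound 3 (1.86 log units; beyond the scatter).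

Compound 4 `CN1C(=S)[C@@H](NC(=O)c2nc(Cc3ccccc3)n(C3CCC3)n2)COc2ccccc21` differs from compound 3 in one place: cyclobutyl in place of isobutyl on an aromatic nitrogen. The isobutyl, with no ring, gives way to a cyclobutyl, one four-membered non-aromatic ring of carbon only, still four heavy atoms on the aromatic nitrogen of the five-membered aromatic ring with three nitrogens.

Within the data shown here, no measured pair shows this exact swap, so the three steps above are the only guide. They show the number climbing steeply as the group on this nitrogen grows from hydrogen through methyl to isopropyl; a group of the same heavy-atom count as isobutyl is therefore expected to stay well above compound 1 and compound 2, with at most a modest move from compound 3 in either direction. Compound 4 is expected to give about 500 nM, within a range from 80 nM to 3000 nM. The expected step is a 2.5-fold lower number from compound 3 to compound 4 (0.39 log units; beyond the scatter), not clearly beyond the scatter.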

Compound 4, half-maximal effective concentration: 181 nM
For compound 4 the middle estimate is 2.8-fold (0.44 log units) above the measured one; low and high end bracket the measured number.
By their numbers in this assay, from the lowest: compound 1; then compound 2; then compound 4; then compound 3.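

In this assay, an equal count of heavy atoms on the aromatic nitrogen does not settle the number: a ring in place of a chain gives a 6.8-fold lower number from compound 3 to compound 4 (0.83 log units; beyond the scatter), so at this position cyclobutyl and isobutyl are clearly told apart. The ring does not recover the numbers of the smaller chains, however, with an 11-fold higher number from compound 2 to compound 4 (1.03 log units; beyond the scatter) when cyclobutyl replaces ethyl and a 72-fold higher number from compound 1 to compound 4 (1.86 log units; beyond the scatter) when it replaces methyl, so methyl remains the group with the lowest number of the four and isobutyl the one with the highest. Nothing measured here explains why the ring and the chain differ.

The compounds shown leave open whether the gain from the ring belongs to cyclobutyl alone or would extend to cyclopropyl or cyclopentyl, and whether any ring on this nitrogen could come as low as methyl does. They also leave open how this position would respond to bare hydrogen, or to a chain carrying an ether oxygen or an amine, and whether the order of these groups would hold with something other than the benzyl group on the neighbouring ring atom.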